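Methylphenyl for Chlorophenyl on a Series Without Measurable Cytotoxicity

The source may report more compounds than this note shows. Statements on the series, on what has been measured and on what is new or still open speak of the compounds shown alone.

Compound 3 `Cc1nc(-c2cccnc2)sc1-c1nnc(-c2ccc(Cl)cc2)o1` was tested in an ADME assay on PANC-1 cells (Homo sapiens) for cytotoxicity, read by MTT assay; on this read-out lower numbers stand for higher toxicity in this test and higher numbers for lower toxicity in this test. In this assay compound 3 gives > 100 ug/mL, which is a limit of the assay and not a number. Compound 1 `Cc1nc(-c2cccnc2)sc1-c1nnc(-c2ccc(Br)cc2)o1` gives > 100 ug/mL, also a limit. Compound 2 `Cc1nc(-c2cccnc2)sc1-c1nnc(-c2ccccc2)o1` gives > 100 ug/mL, again a limit. All three values sit at the same limit (the limit of > 100 ug/mL in this assay, at which 3 of the 3 values shown sit), so the steps a step that the two limits leave unreadable from compound 1 to compound 3 and a step that the two limits leave unreadable from compound 2 to compound 3 cannot be read. Compound 4 `Cc1ccccc1-c1nnc(-c2sc(-c3cccnc3)nc2C)o1` differs from compound 3 by 2-methylphenyl in place of 4-chlorophenyl on an aromatic carbon. No readable step bears on this change; only the shared limit is known. Compound 4 is therefore expected to remain at the limit, estimated at 150 ug/mL, between 70 ug/mL and 400 ug/mL. The expected step is a step that the limit leaves unreadable from compound 3 to compound 4.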

Compound 4, half-maximal cytotoxic concentration: > 100 ug/mL
Compound 4: only a limit was reported (the forecaster's own chance of this, stated with the estimate: 85%); the middle value is on the limit's open side.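

No step can be read in this assay among compound 1, compound 2, compound 3 and compound 4, because each value is a limit of the assay and not a number: the limit of > 100 ug/mL in this assay, at which 4 of the 4 values shown sit.

The compounds shown leave open whether any group at this place moves the read-out off that limit.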